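A ring exchange from compound 1 to compound 4

The compounds below may be only part of what the source reports. "The series", "measured", "known", "first", "only" and "open" are said of these compounds alone.

Measured in an ADME assay on microsomes from liver (Homo sapiens) for metabolic stability; on this read-out lower numbers stand for slow clearance and higher numbers for fast clearance:
- compound 1 `CC(C)Oc1cc(Oc2ccc(S(C)(=O)=O)cc2)cc(-c2cccc(=O)[nH]2)c1`: < 8 mL/min/kg (a limit of the assay, not a number)
- compound 2 `CC(C)Oc1cc(Oc2ccc(S(C)(=O)=O)cc2)cc(-c2cncc(=O)[nH]2)c1`: 11 mL/min/kg
- compound 3 `CC(C)Oc1cc(Oc2ccc(S(C)(=O)=O)cc2)cc(-c2nccc(=O)[nH]2)c1`: < 9.8 mL/min/kg (a limit of the assay, not a number)

Compound 1 stands at < 8 mL/min/kg, which is a limit and not a number. Compound 4 `Cc1cc(=O)[nH]c(-c2cc(Oc3ccc(S(C)(=O)=O)cc3)cc(OC(C)C)c2)n1` has not yet been measured. It departs from compound 1 by a group of 8 heavy atoms (5 carbon, 2 nitrogen, 1 oxygen; one six-membered aromatic ring with 2 hetero atoms) in place of a group of 7 heavy atoms (5 carbon, 1 nitrogen, 1 oxygen; one six-membered aromatic ring with 1 hetero atom), on an aromatic carbon, on an aromatic carbon of a six-membered aromatic ring of carbon only.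

Two measured steps also bring in a six-membered aromatic ring with 2 hetero atoms. One is an at least 1.3-fold higher number from compound 1 to compound 2 (0.13 log units; that floor lies within the scatter). The other is a step that the two limits leave unreadable from compound 1 to compound 3. The two such rings can also be compared directly, in an at least 1.1-fold lower number from compound 2 to compound 3 (0.05 log units; that floor lies within the scatter). None of these steps shows a change beyond the scatter, so no step beyond the scatter is expected in this assay, and no direction can be predicted. The expected size is an at least 1.1-fold higher number from compound 1 to compound 4 (0.05 log units; that floor lies within the scatter). Compound 4 is estimated at 9 mL/min/kg, with an expected range from 4.5 mL/min/kg to 18 mL/min/kg.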

Compound 4, clearance: < 8 mL/min/kg
Compound 4: no number, only a limit; the forecaster's own chance of this, stated with the estimate: 45%; at least 1.1-fold (0.05 log units) between middle value and limit.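

In this assay compound 4 gives < 8 mL/min/kg, which is a limit of the assay and not a number. Among the compounds shown here, the steps from compound 1 and from compound 3 to compound 4 cannot be read, because each has a limit at both ends: the limit of < 8 mL/min/kg in this assay, at which 2 of the 4 values shown sit. The one readable step is an at least 1.3-fold lower number from compound 2 to compound 4 (0.13 log units; that floor lies within the scatter), so the larger group, on an aromatic carbon of a six-membered aromatic ring of carbon only, shows no step beyond the scatter, and the methyl that sets compound 4 apart from compound 3 still leaves a limit rather than a number.

The compounds shown leave open how far compound 1, compound 3 and compound 4 actually lie from one another. They also leave open whether an amine, a carboxylic acid or an ethyl group in place of that methyl would bring a step beyond the scatter.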